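The source may hold more compounds than are shown below. What is called first, only, known or untested is meant among the compounds shown, and "the series" means these compounds.

Measured compounds:
compound 1, `CN1CCN(CCCCCn2c3c(c4ccccc42)C(=O)c2c[n+]([O-])c4ccccc4c2C3=O)CC1`: 1220 nM
compound 2, `O=C1c2c[n+]([O-])c3ccccc3c2C(=O)c2c1c1ccccc1n2CCCCN1CCCCC1`: 200 nM
compound 3, `CN1CCN(CCCCn2c3c(c4ccccc42)C(=O)c2c[n+]([O-])c4ccccc4c2C3=O)CC1`: 10 nM

All three were tested in a functional assay on HCT-116 cells (Homo sapiens) for cytotoxicity, read by MTT assay, with a stated time of 72 h; a higher number here means a weaker inhibitor, a lower number a stronger inhibitor. Compound 3 gives the lowest number of the three in this assay: the nearest is compound 2, a 20-fold lower number from compound 2 to compound 3 (1.30 log units; beyond the scatter), and the furthest is compound 1, a 120-fold lower number from compound 1 to compound 3 (2.09 log units; beyond the scatter). The unmeasured compound 4, `O=C1c2c[n+]([O-])c3ccccc3c2C(=O)c2c1c1ccccc1n2CCCN1CCC(O)CC1`, differs from compound 3 by 4-hydroxypiperidin-1-yl in place of (4-methylpiperazin-1-yl)methyl on a saturated chain carbon, three bonds along the chain from an aromatic nitrogen.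

Two of the measured steps bear on this change. The step of a 20-fold lower number from compound 2 to compound 3 (1.30 log units; beyond the scatter) shows that a 4-methylpiperazin-1-yl group on the chain gives a clearly lower number than piperidin-1-yl, and the step of a 120-fold lower number from compound 1 to compound 3 (2.09 log units; beyond the scatter) shows that adding one more chain atom beyond the 4-methylpiperazin-1-yl group costs much of that gain. Among the compounds with values here, compound 4 replaces the 4-methylpiperazin-1-yl group with a 4-hydroxypiperidin-1-yl group and also changes the chain length, so a higher number than compound 3 is expected, though the hydroxyl on the ring has no measured counterpart here. Compound 4 is therefore estimated at 120 nM (range 25 nM to 600 nM), an expected step of a 12-fold higher number from compound 3 to compound 4 (1.08 log units; beyond the scatter).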

Compound 4, half-maximal inhibitory concentration: 190 nM
Beside the measured number, compound 4's estimate is 1.6-fold (0.20 log units) below it; the measured number falls inside the stated range.
By their numbers in this assay, from the lowest: compound 3; then compounds 4 and 2 (each within the scatter of the next); then compound 1.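

In this assay, the 3-(4-hydroxypiperidin-1-yl)propyl chain does not match the 4-(4-methylpiperazin-1-yl)butyl chain (a 19-fold higher number from compound 3 to compound 4 (1.28 log units; beyond the scatter)), so compound 3 keeps the lowest number of the four. Compound 4 cannot be told apart from compound 2 (a 1.1-fold lower number from compound 2 to compound 4 (0.02 log units; within the scatter)), yet it stays clearly below compound 1 (a 6.4-fold lower number from compound 1 to compound 4 (0.81 log units; beyond the scatter)), so a hydroxyl-bearing ring on this chain fits within the range already seen and does not extend it. Nothing measured here accounts for these steps.

Compound 4 alters both the ring and the chain, so the compounds shown leave open how much of its step from compound 3 belongs to each; a 3-(4-methylpiperazin-1-yl)propyl chain would separate the two. As far as these compounds go, how a morpholin-4-yl or dimethylamino group would behave at the end of this chain also remains open.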